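Fluoro in Place of Methoxy on the Sulfonyl Ring

A few compounds are considered here, and "the series" means these few. Any claim that something is new, unique, unknown or untested is made for them only; others in the source may bear on it.

Of the compounds shown here, three built on one shared core have been tested in a functional assay on SK-MEL-28 cells (Homo sapiens) for cytotoxicity, read by MTT assay; on this read-out lower numbers stand for stronger inhibition and higher numbers for weaker inhibition. Compound 1 `O=C(NCCCNc1nccc(-c2c(-c3cccc(F)c3)nc3sccn23)n1)c1ccc(F)cc1` carries a (4-fluorophenyl)carbonyl group on an amine nitrogen; in this assay compound 1 reaches only the assay limit of > 20000 nM. Compound 2 `O=S(=O)(NCCCNc1nccc(-c2c(-c3cccc(F)c3)nc3sccn23)n1)c1cccc(F)c1` carries a (3-fluorophenyl)sulfonyl group instead and gives 8550 nM, a change of an at least 2.3-fold lower number from compound 1 to compound 2 (0.36 log units; beyond the scatter). Compound 3 `COc1ccc(S(=O)(=O)NCCCNc2nccc(-c3c(-c4cccc(F)c4)nc4sccn34)n2)cc1` carries a (4-methoxyphenyl)sulfonyl group and gives 8980 nM, which is an at least 2.2-fold lower number from compound 1 to compound 3 (0.34 log units; beyond the scatter), while the move a 1.1-fold higher number from compound 2 to compound 3 (0.02 log units; within the scatter). Among the compounds with values here, of the two measured numbers, the one for compound 3 is the highest, yet it sits within the scatter of compound 2, so the two cannot be ranked.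

Compound 4 `O=S(=O)(NCCCNc1nccc(-c2c(-c3cccc(F)c3)nc3sccn23)n1)c1ccc(F)cc1` differs from compound 3 in one place: fluoro in place of methoxy on an aromatic carbon. Within the data shown here, the only measured step that touches the ring on the sulfonyl sulfur, the change from compound 2 to compound 3, stayed within the scatter. The step from compound 3 to compound 4 is therefore expected to be a 1.1-fold lower number from compound 3 to compound 4 (0.02 log units; within the scatter), with no shift beyond the scatter. For compound 4 the estimate in this assay is 8500 nM, with a range from 4000 nM to 18000 nM.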

Compound 4, half-maximal inhibitory concentration: > 20000 nM
Compound 4 ended at the assay's limit; the forecaster's own chance of this, stated with the estimate: 10%; at least 2.3-fold (0.37 log units) between middle value and limit.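

The ring on the sulfonyl sulfur is not as indifferent as the step between compound 2 and compound 3 suggested: in this assay, swapping methoxy for fluoro at the same ring position gives an at least 2.2-fold higher number from compound 3 to compound 4 (0.34 log units; beyond the scatter). Where the fluoro sits also counts, since moving it on that ring gives an at least 2.3-fold higher number from compound 2 to compound 4 (0.36 log units; beyond the scatter), so 4-fluorophenyl behaves differently from both 3-fluorophenyl and 4-methoxyphenyl here. Compound 1 and compound 4 end at one shared limit, which is not a number, so the step between them cannot be read, and the sulfonyl link alone does not ensure a measurable value: the limit of > 20000 nM in this assay, at which 2 of the 4 values shown sit.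

From the compounds shown here alone, what remains open is whether a 4-chlorophenyl, 4-methylphenyl or 4-aminophenyl ring on the sulfonyl sulfur would give a measurable number. The compounds shown also do not explain why fluoro and methoxy part ways at this position.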